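A few compounds are considered here, and "the series" means these few. Any claim that something is new, unique, unknown or untested is made for them only; others in the source may bear on it.

In a functional assay on HCT-116 cells (Homo sapiens) for cytotoxicity (on this read-out higher numbers stand for weaker inhibition and lower numbers for stronger inhibition), compound 1 (`CN1CCN(c2ccc(C(=O)Nc3n[nH]c4cc(C(=O)NC(C)(C)c5ccccc5)sc34)cc2)CC1`) gives 35 nM and compound 2 (`CN1CCN(c2ccc(C(=O)Nc3n[nH]c4cc(C(=O)NC5CCc6ccccc65)sc34)cc2)CC1`) gives 1400 nM, so compound 2 holds the higher of the two numbers and is the weaker inhibitor. Compound 3 (`CN1CCN(c2ccc(C(=O)Nc3n[nH]c4cc(C(=O)NCc5ccccc5)sc34)cc2)CC1`) changes one group of compound 2: benzyl in place of 2,3-dihydro-1H-inden-1-yl on an amide-type nitrogen. Going by the values given here, only one measured step concerns this same amide-type nitrogen, and it is large: a 40-fold higher number from compound 1 to compound 2 (1.60 log units; beyond the scatter). That step shows that a swap here can move the number a long way, but it does not involve benzyl, so it gives no firm direction for the new change. A modest move toward a lower number is expected, and it may not exceed the usual scatter. The estimate amounts to an expected 1.8-fold lower number from compound 2 to compound 3 (0.24 log units; within the scatter). For compound 3, the estimated value is 800 nM, within an expected range of 150 nM to 3000 nM.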

Compound 3, half-maximal inhibitory concentration: 310 nM
Estimate against measurement, compound 3: 2.6-fold (0.41 log units) above; measured number inside the range.
By their numbers in this assay, from the lowest: compound 1; then compound 3; then compound 2.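

In this assay, going from 2,3-dihydro-1H-inden-1-yl to benzyl on the amide-type nitrogen gives a 4.5-fold lower number from compound 2 to compound 3 (0.65 log units; beyond the scatter), so a lower number is possible here without the five-membered non-aromatic ring. Benzyl still falls short of 1-methyl-1-phenylethyl, with an 8.9-fold higher number from compound 1 to compound 3 (0.95 log units; beyond the scatter), which means that all three groups carry a six-membered aromatic ring of carbon yet give clearly different numbers, so that ring alone does not set the value. Nothing measured here explains this order.

From the compounds shown here alone, it remains open whether the aromatic ring is needed at all, which a cyclohexyl group on the same nitrogen would test. A 1-phenylethyl group or a longer 2-phenylethyl chain could also show whether the number changes gradually between benzyl and 1-methyl-1-phenylethyl or follows some other course.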